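The source may hold more compounds than are shown below. What is called first, only, known or untested is meant among the compounds shown, and "the series" means these compounds.

In an ADME assay on J774 cells (Mus musculus) for cytotoxicity, read by resazurin assay, with a stated time of 72 h (a lower number here means that less compound is tolerated, a higher number that more compound is tolerated), compound 1 `C/C(=N\Nc1nc(C)cs1)c1ccc(Cl)c(Cl)c1` gives 33700 nM and compound 2 `C/C(=N\Nc1nc(-c2ccccn2)cs1)c1ccc(Cl)c(Cl)c1` gives 10100 nM. Compound 3 `C/C(=N\Nc1nc(-c2ccc(Cl)cc2)cs1)c1ccc(Cl)c(Cl)c1` reads > 50000 nM, and this is a limit of the assay, not a number.

Compound 4 `COc1ccc(-c2csc(N/N=C(\C)c3ccc(Cl)c(Cl)c3)n2)cc1` differs from compound 3 by one exchange, methoxy in place of chloro on an aromatic carbon, para to a large group, so that 4-chlorophenyl becomes 4-methoxyphenyl: methoxy in place of chloro on an aromatic carbon.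

Within the data shown here, no measured step makes this exact exchange. The nearest ones replace the whole group on the shared core. Pyridin-2-yl in place of methyl gave a 3.3-fold lower number from compound 1 to compound 2 (0.52 log units; beyond the scatter), 4-chlorophenyl in place of methyl gave an at least 1.4-fold higher number from compound 1 to compound 3 (0.17 log units; that floor lies within the scatter), and 4-chlorophenyl in place of pyridin-2-yl gave an at least 4.9-fold higher number from compound 2 to compound 3 (0.69 log units; beyond the scatter). Compound 4 keeps the phenyl of compound 3, and the only clear lowering, in compound 2, came with pyridin-2-yl.

A small move toward a lower number is therefore expected in this assay, possibly none beyond the scatter, and the estimated step is an at least 1.6-fold lower number from compound 3 to compound 4 (0.22 log units; that floor lies within the scatter). For compound 4 the estimated value is 30000 nM, with an expected range from 10000 nM to 50000 nM.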

Compound 4, half-maximal cytotoxic concentration: > 50000 nM
Compound 4 ended at the assay's limit (the forecaster's own chance of this, stated with the estimate: 35%); middle value at least 1.6-fold (0.22 log units) away from the limit.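

In this assay compound 4 gives > 50000 nM, which is a limit of the assay and not a number. The step from compound 3 to compound 4 cannot be read, as both compounds stand at that limit: the limit of > 50000 nM in this assay, at which 2 of the 4 values shown sit. What compound 4 adds is a second substituted phenyl that keeps clear of the lower number seen with pyridin-2-yl, with an at least 4.9-fold higher number from compound 2 to compound 4 (0.69 log units; beyond the scatter), while against the methyl of compound 1 it shows an at least 1.4-fold higher number from compound 1 to compound 4 (0.17 log units; that floor lies within the scatter), so no order can be claimed there.

Going by these compounds, how far compound 3 and compound 4 lie past the limit, and whether chloro and methoxy differ at all, stays open. Also open, on these data alone, is whether an amine or a carboxylic acid on the same aromatic carbon, para to a large group, would bring the number down.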